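Methylating the Ring Amine in a Sulfonyl Series

The compounds below may be only part of what the source reports. "The series", "measured", "known", "first", "only" and "open" are said of these compounds alone.

Compound 3 `O=S(=O)(c1cc(Cl)cc(Cl)c1)c1cn(C2CCCNC2)c2ncccc12` stands second highest of the three compounds measured in a functional assay on HeLa cells for agonist activity at 5-hydroxytryptamine receptor 6 (Homo sapiens), read by cAMP accumulation and immunoassay (on this read-out lower numbers stand for smaller maximal responses and higher numbers for larger maximal responses), where compound 3 gives 62%. Among the compounds with values here, compound 1 `O=S(=O)(c1cccc(Cl)c1)c1cn(C2CCCNC2)c2ncccc12` gives 49%, and the only single-place step recorded, a number 13 percentage points higher from compound 1 to compound 3 (beyond the scatter), concerns chloro on an aromatic carbon and so does not bear on the change at hand. Compound 2 `CN1CCCC(n2cc(S(=O)(=O)c3cccc(F)c3)c3cccnc32)C1` gives 75%; it carries a methyl on the ring amine but also differs elsewhere, so its value is only a hint. Compound 4 `CN1CCCC(n2cc(S(=O)(=O)c3cc(Cl)cc(Cl)c3)c3cccnc32)C1` differs from compound 3 by methyl in place of hydrogen on an amine nitrogen in a ring. Within the data shown here, with no direct precedent, one expects compound 4 to give 68%, within 52% to 84%. The expected step of a number 6 percentage points higher from compound 3 to compound 4 (within the scatter) is thus a small rise, inside the scatter.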

Compound 4, largest response reached (Emax), in percent of the reference or control that the assay uses: 56%
For compound 4 the middle estimate is 12 percentage points above the measured one, and the stated range covers the measured number.
By their numbers in this assay, from the lowest: compounds 1, 4 and 3 (each within the scatter of the next, the first and the last beyond it); then compound 2.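

With methyl in place of hydrogen on the amine nitrogen of the ring, this assay shows a number 6 percentage points lower from compound 3 to compound 4 (within the scatter), so in the 3,5-dichlorophenyl series this nitrogen takes the methyl without a change beyond the scatter. With the methyl held constant, the group on the sulfonyl sulfur does matter: 3,5-dichlorophenyl in place of 3-fluorophenyl gives a number 19 percentage points lower from compound 2 to compound 4 (beyond the scatter). Nothing available explains either step. Still open, going by these compounds, is whether an ethyl or an acetyl group on this nitrogen would behave like methyl, and whether the methyl step holds with 3-fluorophenyl on the sulfonyl sulfur.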